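Series notes: substituent on the ring amine nitrogen

The source may report more compounds than this note shows. Statements on the series, on what has been measured and on what is new or still open speak of the compounds shown alone.

Compound 1 `COc1ccccc1N1CCN(CC(=O)C(O)(c2ccccc2)C2CCC2)CC1` is one of two measured members of the series. In a functional assay on ileum for antagonist activity at muscarinic acetylcholine receptor M3 (Cavia porcellus) (a lower number here means a stronger inhibitor, a higher number a weaker inhibitor), compound 1 gives > 10000 nM, which is a limit of the assay and not a number. Compound 2 `O=C(CN1CCC(N2CCCC2)CC1)C(O)(c1ccccc1)C1CCC1` gives > 10000 nM in this assay, likewise a limit. Both measured values sit together at the limit of > 10000 nM in this assay, at which 2 of the 2 values shown sit, so compound 1 cannot be placed above or below compound 2. Compound 3 `O=C(CN1CCN(C/C=C\c2ccccc2)CC1)C(O)(c1ccccc1)C1CCC1` differs from compound 1 by 3-phenylprop-2-en-1-yl in place of 2-methoxyphenyl on an amine nitrogen in a ring. Within the data shown here, no measured step covers such a change, so no direction is established and the result is expected to remain near the limit. Compound 3 is estimated at 8000 nM, between 1000 nM and 30000 nM, which as an expected step means an at least 1.2-fold lower number from compound 1 to compound 3 (0.09 log units; that floor lies within the scatter).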

Compound 3, antagonist equilibrium constant: 9.92 nM
Compound 3: the middle estimate sits 810-fold (2.91 log units) above what was measured; measured number below the stated range.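

In this assay, 3-phenylprop-2-en-1-yl in place of 2-methoxyphenyl on the amine nitrogen in a ring gives an at least 1000-fold lower number from compound 1 to compound 3 (3.00 log units; beyond the scatter). Compound 3 is thus the first member of the series shown with a value that is not a limit, so a change at this position alone can carry the read-out well clear of it. The step is only a floor, because compound 1 carries a limit and not a number: the limit of > 10000 nM in this assay, at which 2 of the 3 values shown sit.

Which part of 3-phenylprop-2-en-1-yl carries the step stays open. The compounds shown include neither a benzyl group nor a saturated 3-phenylpropyl chain on this nitrogen, so the double bond remains untested apart from the aromatic ring.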